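This account rests on a few compounds, and the source may have more. Where it says the series, first, only, none or still open, it means among the compounds named here.

Measured compounds in a functional assay on A549 cells (Homo sapiens) for cytotoxicity, read by MTT assay, with a stated time of 48 h; a higher number here means a weaker inhibitor, a lower number a stronger inhibitor:

- compound 1 `COc1cccc2[nH]cc(C3(c4c[nH]c5cccc(OC)c45)C(=O)Nc4ccccc43)c12` gives 15300 nM
- compound 2 `COc1ccc2c(C3(c4c[nH]c5cc(OC)ccc45)C(=O)Nc4ccccc43)c[nH]c2c1` gives 7800 nM
- compound 3 `O=C1Nc2ccc(F)cc2C1(c1c[nH]c2ccccc12)c1c[nH]c2ccccc12` gives 12700 nM

All three numbers sit close together. Compound 2 has the lowest of the three numbers, but the gap to compound 3 and the gap to compound 1 both lie within the usual scatter, so no order among them can be claimed. Compounds 1 and 3 differ from compound 2 in more than one place, so none of these pairs gives a single-change step to lean on.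

Compound 4 `COc1ccc2c(C3(c4c[nH]c5cc(OC)ccc45)C(=O)Nc4ccc(F)cc43)c[nH]c2c1` is the next member to be run in this assay. Relative to compound 2 the change is fluoro in place of hydrogen on an aromatic carbon. Among the measured compounds shown here, no measured pair isolates this change. With nothing in the shown data pointing either way, the step from compound 2 to compound 4 is expected to stay within the scatter, as a 1.0-fold lower number from compound 2 to compound 4 (0.02 log units; within the scatter). Compound 4 is therefore estimated at 7500 nM, with a range of 3000 nM to 18000 nM.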

Compound 4, half-maximal inhibitory concentration: 14400 nM
The estimate for compound 4 lay 1.9-fold (0.28 log units) below the measured number; the measured number falls inside the stated range.
By their numbers in this assay, from the lowest: compounds 2, 3, 4 and 1 (each within the scatter of the next).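

In this assay, the series gains its first single-change step: fluoro in place of hydrogen on an aromatic carbon gives a 1.8-fold higher number from compound 2 to compound 4 (0.27 log units; within the scatter). This step lies within the scatter, so the data show no readable effect of fluoro at this position, which is para to a fused ring, on the core of compound 2. Nothing available bears on the reason for this result.

From the compounds shown here alone, it remains open whether chloro, an amine or a carboxylic acid on this same aromatic carbon would give a step beyond the scatter. Also open, going by these compounds, is whether fluoro here would give a similar step with the methoxy groups placed as in compound 1.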